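This account rests on a few compounds, and the source may have more. Where it says the series, first, only, none or still open, it means among the compounds named here.

Measured so far in a functional assay on L1210 cells (Mus musculus) for antiproliferative activity, with a stated time of 48 h; on this read-out higher numbers stand for weaker inhibition and lower numbers for stronger inhibition:
Compound 1 `C=C(Br)C(=O)Nc1ccc(/C=C/C(=O)c2ccc(F)cc2)cc1` gives 1600 nM
Compound 2 `C=C(Br)C(=O)Nc1ccc(/C=C/C(=O)c2cccs2)cc1` gives 250 nM
Compound 3 `Nc1ccc(/C=C/C(=O)c2ccc(F)cc2)cc1` gives 123000 nM

Compound 3 has the highest number of the three, and the large step to it, a 77-fold higher number from compound 1 to compound 3 (1.89 log units; beyond the scatter), comes with hydrogen in place of (1-bromoethenyl)carbonyl on a nitrogen on an aromatic ring. Compound 4 `Cc1ccc(C(=O)/C=C/c2ccc(N)cc2)cc1` has not yet been measured. It departs from compound 3 in a single place, (methyl in place of fluoro on an aromatic carbon), with methyl in place of fluoro on an aromatic carbon, para to a large group.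

Going by the values given here, no measured step makes this exchange. The step at the nitrogen lies elsewhere in the structure and says little about its size. The nearest guide is the modest step of a 6.4-fold lower number from compound 1 to compound 2 (0.81 log units; beyond the scatter), which replaces the whole 4-fluorophenyl group with thiophen-2-yl, but it was measured with the (1-bromoethenyl)carbonyl group present, and compound 3 lacks that group. For this smaller exchange, no step beyond the scatter is expected in this assay, and no direction can be favoured. The expected step is a 1.1-fold lower number from compound 3 to compound 4 (0.05 log units; within the scatter), a change too small to read. Compound 4 is estimated at 110000 nM, with an expected range from 45000 nM to 270000 nM.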

Compound 4, half-maximal inhibitory concentration: 49000 nM
Compound 4: middle estimate off by 2.2-fold (0.35 log units), on the high side; the range from low to high includes it.
By their numbers in this assay, from the lowest: compound 2; then compound 1; then compound 4; then compound 3.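

In this assay, methyl in place of fluoro on an aromatic carbon, para to a large group, gives a 2.5-fold lower number from compound 3 to compound 4 (0.40 log units; beyond the scatter). Going by these compounds alone, this is the first reading of a change at this position alone, since the earlier step on this side of the structure replaced the whole 4-fluorophenyl group with thiophen-2-yl. It shows that exchanging one heavy atom here can move the number beyond the scatter, at least with hydrogen on the nitrogen and no (1-bromoethenyl)carbonyl group; no measurement at hand explains the step.

The compounds shown leave open whether the same exchange has a similar effect when the (1-bromoethenyl)carbonyl group is present. They also leave open how chloro, methoxy, a carboxylic acid or plain hydrogen at this position would compare with methyl and fluoro.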